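Adding a methyl next to the indole nitrogen

A few compounds are considered here, and "the series" means these few. Any claim that something is new, unique, unknown or untested is made for them only; others in the source may bear on it.

Measured compounds:
compound 1, `COC(=O)[C@@]1(C)CCC=C2[C@@H]1CC[C@@H](C)[C@]2(C)Cc1c[nH]c2ccc(C)cc12`: 17000 nM
compound 2, `COC(=O)[C@@]1(C)CCC=C2[C@@H]1CC[C@@H](C)[C@]2(C)Cc1c[nH]c2ccc(OC)cc12`: 2200 nM

Compound 1 has the highest number of the two in a functional assay on A549 cells (Homo sapiens) for inhibition, read by sulforhodamine B assay, with a stated time of 48 h; on this read-out higher numbers stand for weaker inhibition of growth and lower numbers for stronger inhibition of growth; its nearest neighbour, compound 2, sits far lower, and the step of a 7.7-fold lower number from compound 1 to compound 2 (0.89 log units; beyond the scatter) lies beyond the scatter. The unmeasured compound 3, `COC(=O)[C@@]1(C)CCC=C2[C@@H]1CC[C@@H](C)[C@]2(C)Cc1c(C)[nH]c2ccc(C)cc12`, differs from compound 1 by methyl in place of hydrogen on an aromatic carbon; the new group sits on an aromatic carbon of a five-membered aromatic ring with one nitrogen, part of a fused system of two rings, next to the ring nitrogen and next to the ring atom that bears a large group. For the measured compounds named here, the only measured step, a 7.7-fold lower number from compound 1 to compound 2 (0.89 log units; beyond the scatter), concerns a different position and a different kind of exchange, so no measured step bears directly on this change. On that basis no step beyond the scatter is expected in this assay, and compound 3 is estimated to land near compound 1. The expected step of a 1.1-fold lower number from compound 1 to compound 3 (0.05 log units; within the scatter) is therefore small. Compound 3 is expected to give about 15000 nM, within a range from 5000 nM to 45000 nM.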

Compound 3, concentration for 50% growth inhibition: 26000 nM
Compound 3: middle estimate off by 1.7-fold (0.24 log units), on the low side; the range from low to high includes it.
By their numbers in this assay, from the lowest: compound 2; then compounds 1 and 3 (each within the scatter of the next).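

In this assay, methyl in place of hydrogen on an aromatic carbon, next to the ring nitrogen and next to the ring atom that bears a large group, gives a 1.5-fold higher number from compound 1 to compound 3 (0.18 log units; within the scatter), so on this read-out compound 1 and compound 3 cannot be told apart. For the compounds shown here, the earlier step, a 7.7-fold lower number from compound 1 to compound 2 (0.89 log units; beyond the scatter), concerned a different place and a different exchange, so this is the first sign that one added methyl at this position, on the background of compound 1, neither clearly gains nor clearly loses growth inhibition. No supporting measurement is available to explain why this position gives so small a step.

From the compounds shown here alone, whether this position would accept more than a methyl stays open: a longer chain such as propyl, a phenyl ring or an amine could give a step beyond the scatter or stay within it. Going by these compounds, it is also open whether the same methyl would give so small a step on compound 2, which already has a methoxy elsewhere and starts from a clearly lower number.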